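This account rests on a few compounds, and the source may have more. Where it says the series, first, only, none or still open, it means among the compounds named here.

In a functional assay on UMUC3 cells (Homo sapiens) for antiproliferative activity, read by MTT assay, with a stated time of 72 h (on this read-out higher numbers stand for weaker inhibition and lower numbers for stronger inhibition), compound 1 `CC(C)CNC(=N)NC(=N)Nc1ccc(F)cc1F` reads 17300 nM and compound 2 `CC(C)CNC(=N)NC(=N)Nc1ccc(F)c(F)c1` reads 7100 nM (the lower of the two numbers, with a gap beyond the scatter). Compound 3 `N=C(NC(=N)NC1CCCC1)Nc1ccc(F)c(F)c1` carries cyclopentyl in place of isobutyl on an amine nitrogen. For the measured compounds named here, no measured pair shows this change, so the expectation rests on the structural change alone, and no step beyond the scatter is expected in this assay for it. The expected step of a 1.3-fold lower number from compound 2 to compound 3 (0.11 log units; within the scatter) is small. For compound 3 the estimated value is 5500 nM (expected range 2200 nM to 13000 nM).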

Compound 3, half-maximal inhibitory concentration: 7200 nM
The estimate for compound 3 lay 1.3-fold (0.12 log units) below the measured number; measured number inside the range.
By their numbers in this assay, from the lowest: compounds 2 and 3 (each within the scatter of the next); then compound 1.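

Cyclopentyl in place of isobutyl on an amine nitrogen gives a 1.0-fold higher number from compound 2 to compound 3 (0.01 log units; within the scatter) in this assay, so at this position one five-membered non-aromatic ring of carbon only stands in for isobutyl without a step beyond the scatter. Compound 1 and compound 2 both carry isobutyl, so they could not show this. Nothing measured here bears on why the two numbers lie so close. Open, on these data alone, is whether a longer chain, a cyclohexyl ring or a carboxylic acid on this nitrogen would read alike. Also open, as far as these compounds go, is whether the same change would read alike on the core of compound 1.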